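The source may report more compounds than this note shows. Statements on the series, on what has been measured and on what is new or still open speak of the compounds shown alone.

Measured compounds in an assay on HEK293 cells for displacement of a labelled ligand from 5-hydroxytryptamine receptor 3A (Homo sapiens), read by scintillation counting, with a stated time of 24 h, in the presence of a further agent that is not named here; on this read-out lower numbers stand for stronger inhibition and higher numbers for weaker inhibition:
compound 1 `CN1CCN(c2nc(N(C)C)c3cc(Cl)ccc3n2)CC1`: 6.61 nM
compound 2 `CN1CCN(c2nc(NCC3CCCCC3)c3cc(Cl)ccc3n2)CC1`: 16600 nM

For the measured compounds named here, compound 2 gives the higher of the two numbers; its nearest neighbour is compound 1, and the step of a 2500-fold higher number from compound 1 to compound 2 (3.40 log units; beyond the scatter) is the only one measured so far. Compound 3 `CN1CCN(c2nc(NCc3ccc(N)cc3)c3cc(Cl)ccc3n2)CC1` differs from compound 2 in one place: 4-aminophenyl in place of cyclohexyl on a saturated chain carbon bound to a nitrogen on an aromatic ring. Going by the values given here, no measured step concerns this kind of exchange; the step from compound 1 to compound 2 replaces a small group with a larger one and does not compare a saturated ring with an aromatic ring of similar size. The expectation therefore rests mainly on compound 2, which keeps its large substituent on the same nitrogen. Compound 3 is expected to remain near compound 2, with at most a modest move a 2.1-fold lower number from compound 2 to compound 3 (0.32 log units; beyond the scatter) that may not exceed the scatter. The estimate for compound 3 in this assay is 8000 nM, within a range of 1500 nM to 40000 nM.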

Compound 3, inhibition constant: 2.69 nM
Estimate against measurement, compound 3: 3000-fold (3.47 log units) above, and the stated range ends above it.
By their numbers in this assay, from the lowest: compound 3; then compound 1; then compound 2.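

In this assay, a large group on this nitrogen does not by itself raise the number: a 6200-fold lower number from compound 2 to compound 3 (3.79 log units; beyond the scatter), and this exchange reverses the loss seen in a 2500-fold higher number from compound 1 to compound 2 (3.40 log units; beyond the scatter). The result also goes further than recovery, with a 2.5-fold lower number from compound 1 to compound 3 (0.39 log units; beyond the scatter), so (4-aminobenzyl)amino is better tolerated than dimethylamino on this aromatic carbon, while (cyclohexylmethyl)amino is not. The exchange changes the ring from saturated to aromatic and adds the amine in one step, and no measurement shown explains the result.

The compounds shown do not separate the contribution of the aromatic ring from that of the amine, which unsubstituted benzyl and 4-hydroxybenzyl would address. As far as these compounds go, it also remains open whether this result holds with a longer chain, such as 2-(4-aminophenyl)ethyl, on the same nitrogen.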